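This account rests on a few compounds, and the source may have more. Where it says the series, first, only, none or still open, it means among the compounds named here.

Measured compounds:
compound 1 `Cc1cccc(Cn2c(CN3CCN(C(=O)c4ccc(C(F)(F)F)cc4)CC3)nc3ccccc32)c1` – 22.9%
compound 2 `Cc1cccc(Cn2c(CN3CCN(C(=O)c4ccc(Cl)cc4)CC3)nc3ccccc32)c1` – 23.2%

Going by the values given here, in an assay on isolated protein for inhibition of aldehyde dehydrogenase 1A1 (Homo sapiens), read by spectrophotometry, tested at 10 uM (on this read-out lower numbers stand for less inhibition and higher numbers for more inhibition at the one concentration tested (going by the name of the read-out)), compound 2 gives 23.2%, the higher of the two numbers so far, yet its only neighbour, compound 1, sits so close that the pair cannot be ranked: the step of a number 0.3 percentage points higher from compound 1 to compound 2 (within the scatter) lies within the scatter. Both compounds inhibit only weakly at the concentration tested.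

Compound 3 `CCC(=O)N1CCN(Cc2nc3ccccc3n2Cc2cccc(C)c2)CC1` differs from compound 2 in one place: ethyl in place of 4-chlorophenyl on a carbonyl carbon. Among the compounds with values here, the one measured step, a number 0.3 percentage points higher from compound 1 to compound 2 (within the scatter), only swaps a substituent on the aromatic ring that now leaves altogether, so it says little about removing that ring and leaving a short chain on the carbonyl carbon. Within the data shown here, no measured pair covers such a change. With a starting point already near the low end of the read-out, the room for a large fall is small, and the step is expected to be modest.

Compound 3 is therefore expected to give 13%, between 0% and 28%, a step of a number 10.2 percentage points lower from compound 2 to compound 3 (beyond the scatter) that may not exceed the scatter.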

Compound 3, a percentage reported as inhibition, at one concentration (the size of the read-out at that concentration, not a potency): 85.1%
The estimate for compound 3 lay 72.1 percentage points below the measured number, and the stated range ends below it.
By their numbers in this assay, from the lowest: compounds 1 and 2 (each within the scatter of the next); then compound 3.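

In this assay, the group on the carbonyl carbon turns out to matter far more than the first two compounds could show: ethyl in place of 4-chlorophenyl gives a number 61.9 percentage points higher from compound 2 to compound 3 (beyond the scatter) and ethyl in place of 4-(trifluoromethyl)phenyl gives a number 62.2 percentage points higher from compound 1 to compound 3 (beyond the scatter) in the same direction. Going by these compounds alone, the earlier pair changed only the substituent on the aromatic ring, and that step, a number 0.3 percentage points higher from compound 1 to compound 2 (within the scatter) as printed, gave no hint that replacing the whole ring with a short chain could shift the read-out so far, so the large change so far belongs to the ring-to-ethyl swap and not to the swap of chloro for trifluoromethyl. Nothing available from other measurements speaks to why the propanoyl compound behaves so differently from the two aromatic amides.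

These three compounds cannot separate the effect of losing the aromatic ring from the effect of having ethyl in particular. An unsubstituted phenyl, a cyclohexyl, a methyl, a longer chain such as butyl, or an amine such as dimethylamino on the same carbonyl carbon would each help to tell those two readings apart.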